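Swapping phenyl for tert-butyl on a shorter linker

A few compounds are considered here, and "the series" means these few. Any claim that something is new, unique, unknown or untested is made for them only; others in the source may bear on it.

Three sulfonamides have been tested in a functional assay on MIA PaCa-2 cells (Homo sapiens) for inhibition, read by MTT assay, with a stated time of 72 h; a lower number here means a stronger inhibitor of growth, a higher number a weaker inhibitor of growth. Compound 3 `O=S(=O)(NCCCNCc1ccc(-c2ccccc2)cc1)c1cc(C(F)(F)F)cc(C(F)(F)F)c1` gives 2400 nM. Compound 1 `CC(C)(C)c1ccc(CNCCCNS(=O)(=O)c2cc(C(F)(F)F)cc(C(F)(F)F)c2)cc1` differs from it by tert-butyl in place of phenyl on an aromatic carbon and gives 2300 nM, a step of a 1.0-fold lower number from compound 3 to compound 1 (0.02 log units; within the scatter). Compound 2 `O=S(=O)(NCCNCc1ccc(-c2ccccc2)cc1)c1cc(C(F)(F)F)cc(C(F)(F)F)c1` gives 2700 nM; the difference between the core of compound 2 and the core of compound 3 is not broken down here. Compound 4 `CC(C)(C)c1ccc(CNCCNS(=O)(=O)c2cc(C(F)(F)F)cc(C(F)(F)F)c2)cc1` has not yet been measured. It differs from compound 2 by tert-butyl in place of phenyl on an aromatic carbon, the same change that separates compound 3 from compound 1. Since that change moved the number only by a 1.0-fold lower number from compound 3 to compound 1 (0.02 log units; within the scatter), the expected step is a 1.0-fold lower number from compound 2 to compound 4 (0.02 log units; within the scatter). Compound 4 is therefore estimated at 2600 nM, with a likely range from 1300 nM to 5200 nM.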

Compound 4, concentration for 50% growth inhibition: 15000 nM
Beside the measured number, compound 4's estimate is 5.8-fold (0.76 log units) below it; measured number outside the range, above it.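

In this assay, the swap on the core of compound 2 gives a 5.6-fold higher number from compound 2 to compound 4 (0.74 log units; beyond the scatter), so the change did not carry over unaltered from one core to the other: the same change on two cores in this assay, a 1.0-fold lower number (0.02 log units; within the scatter) from compound 3 to compound 1 and a 5.6-fold higher number (0.74 log units; beyond the scatter) from compound 2 to compound 4, 5.8-fold (0.76 log units) apart, beyond the scatter of two such steps. For these two pairs, then, the effect of replacing phenyl with tert-butyl depends on the core that carries it, and the step on one core is a poor guide to the step on the other. Among the compounds shown here, with only two pairs, the data do not show why the cores differ or which result is more typical of the series.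

As far as these compounds go, it remains open how the same swap would behave on a core with a longer chain in the linker. From the compounds shown here alone, it is also open whether a smaller group, such as methyl, would follow either pair.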